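Swapping Methyl for Chloro in a Cytotoxicity Series

The source may report more compounds than this note shows. Statements on the series, on what has been measured and on what is new or still open speak of the compounds shown alone.

Three related amides have been tested in a functional assay on BGC-823 cells (Homo sapiens) for cytotoxicity, read by CCK-8 assay, with a stated time of 24 h; on this read-out higher numbers stand for weaker inhibition and lower numbers for stronger inhibition. Compound 1 `C/C(=C\c1ccc(-c2ccc(F)cc2)o1)C(N)=O` gives 940 nM. Compound 2 `C/C(=C\c1cc(-c2ccc(C)cc2)cs1)C(N)=O` reaches only the assay limit of > 50000 nM, which is not a number. Compound 3 `C/C(=C\c1cccc(-c2ccccc2)c1)C(N)=O` likewise sits at the limit of > 50000 nM. Compound 2 therefore stands among the weakest members shown, as the limit of > 50000 nM in this assay, at which 2 of the 3 values shown sit, records. Compound 4 `C/C(=C\c1cc(-c2ccc(Cl)cc2)cs1)C(N)=O` differs from compound 2 by one exchange, (chloro in place of methyl on an aromatic carbon), that is, chloro in place of methyl on an aromatic carbon. Among the compounds with values here, no measured pair shows what this swap does here, so there is no direct guide. The step of a number no higher from compound 2 to compound 4 (the limit leaves the size open) is expected to be no larger than the usual scatter, most likely another limit. Compound 4 is estimated at 50000 nM, within 15000 nM to 100000 nM.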

Compound 4, half-maximal inhibitory concentration: > 50000 nM
Compound 4: no number, only a limit (the forecaster's own chance of this, stated with the estimate: 65%); the middle value sits exactly at the limit.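

Within the data shown here, compound 2 and compound 4 both give only a limit rather than a number, so no step between them can be read. As far as these compounds go, how chloro in place of methyl on an aromatic carbon changes cytotoxicity in this assay stays open.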